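Removing a Methyl From the Highest Scorer

A few compounds are considered here, and "the series" means these few. Any claim that something is new, unique, unknown or untested is made for them only; others in the source may bear on it.

For the measured compounds named here, in a functional assay on HCT-116 cells (Homo sapiens) for antiproliferative activity, read by CCK-8 assay, with a stated time of 72 h, tested at 2 uM (a higher number here means a stronger effect of the compound at the concentration tested, a lower number a weaker effect), compound 2 `Cc1ccc(Nc2nc(Cl)nc3c2ncn3Cc2ccc(C(=O)Nc3ccccc3N)cc2)cc1` gives 76.3%, the higher of the two numbers known, while compound 1 `CCCCn1cnc2c(Nc3cccc(Cl)c3)nc(NCOCc3ccc(/C=C/C(=O)Nc4ccccc4N)cc3)nc21` gives 4.76%, a gap beyond the scatter. Compound 3 `Nc1ccccc1NC(=O)c1ccc(Cn2cnc3c(Nc4ccccc4)nc(Cl)nc32)cc1` has not yet been measured in this assay. It differs from compound 2 by hydrogen in place of methyl on an aromatic carbon. Going by the values given here, with no step between measured compounds to draw on, this change is expected to move this assay little, if at all beyond the scatter, perhaps slightly downward. Compound 3 is therefore estimated at 70%, between 50% and 85%. This corresponds to an expected step of a number 6.3 percentage points lower from compound 2 to compound 3 (within the scatter).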

Compound 3, a percentage reported as inhibition, at one concentration (the size of the read-out at that concentration, not a potency): 71.4%
Beside the measured number, compound 3's estimate is 1.4 percentage points below it; measured number inside the range.
By their numbers in this assay, from the lowest: compound 1; then compounds 3 and 2 (each within the scatter of the next).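

In this assay, for the compounds shown here, the change from 4-methylphenyl to phenyl gives a number 4.9 percentage points lower from compound 2 to compound 3 (within the scatter), the first comparison in which a single place differs. The methyl on this aromatic carbon can therefore be lost without a change beyond the scatter at the one concentration tested, which compound 1, differing from compound 2 in several places, could not show. Nothing available explains this result.
As far as these compounds go, only methyl and hydrogen are compared at this place, so the effect of a methoxy group, a chlorine or an amine there remains open.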